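Aryl exchange on the triazole nitrogen of one series

The source may hold more compounds than are shown below. What is called first, only, known or untested is meant among the compounds shown, and "the series" means these compounds.

Working notes. Compound 3 `Cc1ccc(Cl)cc1-n1nncc1CN1C(=O)C2(C(C#N)=C(N)Oc3c(N)cc4nc5ccccc5nc4c32)c2ccccc21` carries a 5-chloro-2-methylphenyl group on an aromatic nitrogen of a five-membered aromatic ring with 3 nitrogen. In an ADME assay on L02 cells (Homo sapiens) for antiproliferative activity, read by MTT assay, with a stated time of 48 h (on this read-out lower numbers stand for stronger inhibition and higher numbers for weaker inhibition), compound 3 gives > 50000 nM, which is a limit of the assay and not a number. Compound 1 `CC(=O)Nc1ccc(-n2nncc2CN2C(=O)C3(C(C#N)=C(N)Oc4c(N)cc5nc6ccccc6nc5c43)c3ccccc32)cc1` in this assay gives > 50000 nM, also a limit. Compound 2 `CCOc1ccc(-n2nncc2CN2C(=O)C3(C(C#N)=C(N)Oc4c(N)cc5nc6ccccc6nc5c43)c3ccccc32)cc1` in this assay gives > 50000 nM, again a limit. The steps a step that the two limits leave unreadable from compound 1 to compound 2, a step that the two limits leave unreadable from compound 1 to compound 3 and a step that the two limits leave unreadable from compound 2 to compound 3 are therefore of unknown size; what the series shows is the limit of > 50000 nM in this assay, at which 3 of the 3 values shown sit.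

Compound 4 `N#CC1=C(N)Oc2c(N)cc3nc4ccccc4nc3c2C12C(=O)N(Cc1cnnn1-c1ccc([N+](=O)[O-])cc1[N+](=O)[O-])c1ccccc12` differs from compound 3 by 2,4-dinitrophenyl in place of 5-chloro-2-methylphenyl on an aromatic nitrogen. The three measured steps touch the same aromatic nitrogen, but none of them can be sized, so no direction can be drawn from them for this exchange. Compound 4 is expected to give 70000 nM in this assay, with a range of 20000 nM to 250000 nM, and most probably to be reported again as a limit. The expected step that the limit leaves unreadable from compound 3 to compound 4 is taken to be none beyond the scatter.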

Compound 4, half-maximal inhibitory concentration: 22800 nM
Compound 4: the middle estimate sits 3.1-fold (0.49 log units) above what was measured; the measured number falls inside the stated range.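

In this assay, this aromatic nitrogen now shows that the aryl group it carries can move the read-out: exchange for 2,4-dinitrophenyl gives an at least 2.1-fold lower number from compound 3 to compound 4 (0.34 log units; beyond the scatter), an at least 2.1-fold lower number from compound 2 to compound 4 (0.34 log units; beyond the scatter) and an at least 2.1-fold lower number from compound 1 to compound 4 (0.34 log units; beyond the scatter). All three steps are bounds rather than exact sizes, and they run the same way whichever of the three aryl groups leaves. The steps among compound 1, compound 2 and compound 3 still cannot be read, so only compound 4 gives a number, with the rest of the series held at a limit: the limit of > 50000 nM in this assay, at which 3 of the 4 values shown sit.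

As far as these compounds go, whether both nitro groups are needed for the lower number remains open. From the compounds shown here alone, it is also open how a plain phenyl, a phenyl with a single nitro group, or a phenyl bearing an amine or a carboxylic acid would read here.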